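An Added Amino Group on a Core Without Measurable Inhibition

The compounds below may be only part of what the source reports. "The series", "measured", "known", "first", "only" and "open" are said of these compounds alone.

Compound 1 `CCc1nc(N)ncc1-c1ccc(C(F)(F)F)cc1` was tested in an assay for inhibition of beta-N-acetyl-D-hexosaminidase-A/B (Homo sapiens); a lower number here means a stronger inhibitor, a higher number a weaker inhibitor. In this assay compound 1 gives > 400000 nM, which is a limit of the assay and not a number. Compound 2 `CCc1nc(N)ncc1-c1ccc(Cl)cc1` differs from compound 1 only by chloro in place of trifluoromethyl on an aromatic carbon. In this assay compound 2 gives > 400000 nM, again a limit. The step that the two limits leave unreadable from compound 1 to compound 2 therefore cannot be read. Compound 3 `CCCCc1nc(N)nc(N)c1-c1ccc(Cl)cc1` carries two amino groups on the shared core together with a butyl chain. In this assay compound 3 gives > 1400000 nM, a limit as well. Of the three values shown, one sits at the limit of > 1400000 nM in this assay, at which 1 of the 3 values shown sits, and two sit at the limit of > 400000 nM in this assay, at which 2 of the 3 values shown sit, so compound 1 stands at a limit with no measured number anywhere around it.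

Compound 4 `CCc1nc(N)nc(N)c1-c1ccc(C(F)(F)F)cc1` differs from compound 1 by amino in place of hydrogen on an aromatic carbon. Among the compounds with values here, no measured step covers this change, and the only measured step, a step that the two limits leave unreadable from compound 1 to compound 2, has no readable size. Compound 3 also carries an amino group at this place, and its value is a limit too. No step beyond the scatter can therefore be expected. Compound 4 is expected to give about 1000000 nM, within 300000 nM to 5000000 nM, most likely reported as a limit rather than a number. The expected step that the limit leaves unreadable from compound 1 to compound 4 is thus estimated to be none beyond the scatter.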

Compound 4, half-maximal inhibitory concentration: 15000 nM
Beside the measured number, compound 4's estimate is 67-fold (1.82 log units) above it; the whole stated range lies above it.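

In this assay, amino in place of hydrogen on an aromatic carbon gives an at least 26-fold lower number from compound 1 to compound 4 (1.42 log units; beyond the scatter), which makes this place, next to the ring nitrogen and ortho to a large group, the first in the set where a single change yields a measured number instead of a limit. The starting point of this step is itself only a limit, so the real gap between the two compounds may be wider than the printed one. The amino group does not bring a measured number in every compound shown, since compound 3 also carries it and still stands at a limit of the assay and not a number: the limit of > 1400000 nM in this assay, at which 1 of the 4 values shown sits.

Compound 3 differs from compound 4 in both its butyl chain and its chloro, so the compounds shown cannot say which of these two places holds its value at a limit. As far as these compounds go, it also stays open whether a different small group at this same place, such as hydroxyl, methyl or methylamino, would match the amino group, or whether the amino group itself is needed for the gain.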